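A Substituted Phenyl Swap in a Shared Aryl Urea Series

The source may hold more compounds than are shown below. What is called first, only, known or untested is meant among the compounds shown, and "the series" means these compounds.

Of the compounds shown here, three built on one shared core have been measured in a functional assay on HT-29 cells (Homo sapiens) for cytotoxicity, read by MTT assay, with a stated time of 72 h; on this read-out lower numbers stand for stronger inhibition and higher numbers for weaker inhibition. Compound 1 `COc1ccc(/C=N/NC(=O)Nc2ccc(Oc3ccnc4cc(OCCCN5CCCCC5)c(OC)cc34)c(F)c2)cc1` gives 590 nM. Compound 2 `COc1cc2c(Oc3ccc(NC(=O)N/N=C/c4ccc(F)cc4Cl)cc3F)ccnc2cc1OCCCN1CCCCC1` gives 260 nM, and compound 3 `COc1cc2c(Oc3ccc(NC(=O)N/N=C/c4ccc(N(C)C)cc4)cc3F)ccnc2cc1OCCCN1CCCCC1` gives 1000 nM. Compound 3 thus has the highest number of the three: a 3.8-fold higher number from compound 2 to compound 3 (0.59 log units; beyond the scatter), while a 1.7-fold higher number from compound 1 to compound 3 (0.23 log units; within the scatter). Compound 4 `C=CCc1cccc(/C=N/NC(=O)Nc2ccc(Oc3ccnc4cc(OCCCN5CCCCC5)c(OC)cc34)c(F)c2)c1OC` differs from compound 3 in one place: 3-allyl-2-methoxyphenyl in place of 4-(dimethylamino)phenyl on a carbon with a double bond to nitrogen. Within the data shown here, the steps that bear on this change are those that exchange the aryl group on the same carbon: a 2.3-fold lower number from compound 1 to compound 2 (0.36 log units; beyond the scatter) and a 3.8-fold higher number from compound 2 to compound 3 (0.59 log units; beyond the scatter), whereas a 1.7-fold higher number from compound 1 to compound 3 (0.23 log units; within the scatter). Compound 4 bears a methoxy group on its phenyl ring, as compound 1 does, together with an allyl group; the measured steps give no guidance on the allyl group. Because compound 1 gives 590 nM with a methoxyphenyl, compound 4 is expected to show a 2.0-fold lower number from compound 3 to compound 4 (0.30 log units; within the scatter) in this assay. Compound 4 is estimated at 500 nM, with a range from 200 nM to 1300 nM.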

Compound 4, half-maximal inhibitory concentration: 460 nM
For compound 4 the middle estimate is 1.1-fold (0.04 log units) above the measured one; measured number inside the range.
By their numbers in this assay, from the lowest: compounds 2, 4, 1 and 3 (each within the scatter of the next, the first and the last beyond it).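

In this assay, the 3-allyl-2-methoxyphenyl group on the carbon with a double bond to nitrogen separates from the 4-(dimethylamino)phenyl group, with a 2.2-fold lower number from compound 3 to compound 4 (0.34 log units; beyond the scatter). It does not separate from the other two aryl groups, with a 1.8-fold higher number from compound 2 to compound 4 (0.25 log units; within the scatter) and a 1.3-fold lower number from compound 1 to compound 4 (0.11 log units; within the scatter), so a group with an allyl substituent can stand at this position without leaving the range that the 2-chloro-4-fluorophenyl and 4-methoxyphenyl groups span. No measurement is available that explains these steps.

Going by these compounds, compound 4 brings in the allyl and methoxy groups together, so what each contributes on its own remains open. A propyl chain in place of the allyl group, or an amine or a carboxylic acid on the same phenyl ring, would test how far this position accepts other groups.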